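Compound 2 to its isopropylcarbonyl counterpart

The source may hold more compounds than are shown below. What is called first, only, known or untested is meant among the compounds shown, and "the series" means these compounds.

In a functional assay on K562 cells (Homo sapiens) for cytotoxicity, read by MTT assay (a higher number here means a weaker inhibitor, a lower number a stronger inhibitor), compound 1 `COc1ccc(/C=C/C(=O)c2ccc(OC)c3c2OC(C)(C)C=C3)cc1OCCO` gives 8750 nM. Compound 2 `COc1ccc(/C=C/C(=O)c2ccc(OC)c3c2OC(C)(C)C=C3)cc1OCCCN(C)C` gives 2920 nM, the lower of the two numbers. Compound 3 `COc1ccc(/C=C/C(=O)c2ccc(OC)c3c2OC(C)(C)C=C3)cc1OC(=O)C(C)C` has isopropylcarbonyl in place of 3-(dimethylamino)propyl on an oxygen on an aromatic ring. Among the measured compounds shown here, only one measured step bears on this change: a 3.0-fold lower number from compound 1 to compound 2 (0.48 log units; beyond the scatter), a modest gain on gaining the dimethylamino end. Compound 3 also lacks that end, so a modest step of similar size towards a higher number is expected, though an ester has not yet been measured. The expected step is a 2.1-fold higher number from compound 2 to compound 3 (0.31 log units; beyond the scatter). For compound 3 the estimate is 6000 nM, with an expected range of 2500 nM to 14000 nM.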

Compound 3, half-maximal inhibitory concentration: 570 nM
Compound 3: middle estimate off by 11-fold (1.02 log units), on the high side, and the stated range ends above it.
By their numbers in this assay, from the lowest: compound 3; then compound 2; then compound 1.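

At the oxygen on an aromatic ring, a dimethylamino end is not required for a low number in this assay or for the lowest of these three: isopropylcarbonyl replacing 3-(dimethylamino)propyl gives a 5.1-fold lower number from compound 2 to compound 3 (0.71 log units; beyond the scatter) and, replacing 2-hydroxyethyl, a 15-fold lower number from compound 1 to compound 3 (1.19 log units; beyond the scatter) in the same direction. The first step alone had pointed towards the amine end, but the ester, with no amine, outranks both ether-linked compounds. No evidence here accounts for this difference.

Still open, going by these compounds, is whether the gain follows the ester carbonyl or the isopropyl part. An acetyl ester, a benzoyl ester and the free hydroxy group at this oxygen would separate the two.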